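This account rests on a few compounds, and the source may have more. Where it says the series, first, only, none or still open, it means among the compounds named here.

Compound 1 `O=C(O)c1cccc(-c2ccc(N3CCC(Oc4ccccc4C(F)(F)F)CC3)nn2)c1` gives 107 nM in an assay on isolated protein for inhibition of acyl-CoA desaturase 1 (Rattus norvegicus); a higher number here means a weaker inhibitor, a lower number a stronger inhibitor.
Compound 2 `O=C(O)c1cncc(-c2ccc(N3CCC(Oc4ccccc4C(F)(F)F)CC3)nn2)c1` gives 129 nM in this assay.

For the measured compounds named here, compound 2 has the higher of the two numbers, but the only measured step, a 1.2-fold higher number from compound 1 to compound 2 (0.08 log units; within the scatter), lies within the scatter, so the two compounds cannot be told apart. Compound 3 `O=C(O)c1cncc(-c2ccc(N3CCC(Oc4ccccc4Cl)CC3)nn2)c1` differs from compound 2 in another place: chloro in place of trifluoromethyl on an aromatic carbon. Going by the values given here, no measured step touches this part of the molecule, so nothing here shows how this assay responds to it; the expectation rests on compound 2 alone. A step of a 1.6-fold higher number from compound 2 to compound 3 (0.19 log units; within the scatter) is expected, small and uncertain in direction. Compound 3 is therefore estimated at 200 nM, between 70 nM and 600 nM.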

Compound 3, half-maximal inhibitory concentration: 166 nM
Compound 3: the middle estimate sits 1.2-fold (0.08 log units) above what was measured; the measured number falls inside the stated range.
By their numbers in this assay, from the lowest: compounds 1, 2 and 3 (each within the scatter of the next).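

In this assay, putting chloro in place of trifluoromethyl on the aromatic carbon gives a 1.3-fold higher number from compound 2 to compound 3 (0.11 log units; within the scatter), so the two groups cannot be told apart at this position. The swap replaces 4 heavy atoms with 1, and the number stays within the scatter. Nothing measured here bears on why the two groups read alike.

Still open, from the compounds shown here alone, is whether a methoxy group, an amine or a longer chain at this position would read the same. Going by these compounds, it is also open whether chloro would match trifluoromethyl with the 3-carboxyphenyl of compound 1.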